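The compounds below may be only part of what the source reports. "The series", "measured", "known", "first", "only" and "open" are said of these compounds alone.

Measured so far in an in vitro functional assay on HEK285-7 cells for antagonist activity at prostaglandin D2 receptor 2 (Homo sapiens), read by BRET and beta-arrestin recruitment; on this read-out lower numbers stand for stronger inhibition and higher numbers for weaker inhibition:

compound 1, `Cc1nc(-c2ccc(Cl)cc2)c(CC(=O)O)s1`, gives 41000 nM
compound 2, `O=C(O)Cc1sc(C(c2ccccc2)c2ccccc2)nc1-c1ccc(F)cc1`, gives 77 nM
compound 3, `O=C(O)Cc1sc(C(c2ccc(F)cc2)c2ccc(F)cc2)nc1-c1cccc(F)c1`, gives 18 nM

Compound 3 has the lowest number of the three, with compound 2 the nearest and compound 1 far behind, both gaps beyond the usual scatter. The next compound, compound 4, `O=C(O)Cc1sc(C(c2ccc(F)cc2)c2ccc(F)cc2)nc1-c1ccnc(O)c1`, has not yet been tested. It differs from compound 3 in one place: 2-hydroxypyridin-4-yl in place of 3-fluorophenyl on an aromatic carbon. Among the measured compounds shown here, no pair of measured compounds shows what a swap of this kind does, so the direction of the step can only be guessed. The hydrogen-bond donor and acceptors that enter are new to this series, and a moderate weakening is expected, with compound 4 staying well below compound 1. The expected step of a 3.3-fold higher number from compound 3 to compound 4 (0.52 log units; beyond the scatter) is a modest loss. Compound 4 is estimated at 60 nM, between 15 nM and 300 nM.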

Compound 4, half-maximal inhibitory concentration: 890 nM
The estimate for compound 4 lay 15-fold (1.17 log units) below the measured number; measured number outside the range, above it.
By their numbers in this assay, from the lowest: compound 3; then compound 2; then compound 4; then compound 1.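

In this assay, this position on the shared core proves highly sensitive to the ring it carries: 2-hydroxypyridin-4-yl in place of 3-fluorophenyl, a swap that keeps a six-membered aromatic ring, gives a 49-fold higher number from compound 3 to compound 4 (1.69 log units; beyond the scatter). Among the compounds shown here, this is the first step measured at this position. Nothing shown explains the loss.

As far as these compounds go, the swap brings in the ring nitrogen and the hydroxy group together, so their separate contributions remain open. Pyridin-4-yl without the hydroxy group, or 2-methoxypyridin-4-yl, would help separate them.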